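A few compounds are considered here, and "the series" means these few. Any claim that something is new, unique, unknown or untested is made for them only; others in the source may bear on it.

In an ADME assay on MDCK cells (Canis lupus familiaris) for cytotoxicity, read by MTT assay, with a stated time of 24 h (a lower number here means that less compound is tolerated, a higher number that more compound is tolerated), compound 1 `Cc1cc(CNS(=O)(=O)c2ccc([N+](=O)[O-])cc2)c(C)o1` gives > 152000 nM, a limit of the assay and not a number. Compound 1 thus stands at the limit of > 152000 nM in this assay, at which 1 of the 2 values shown sits.

Moving to compound 3 `Cc1cc(CNS(=O)(=O)c2ccc(F)cc2)c(C)o1` puts fluoro in place of nitro on an aromatic carbon, para to a large group: fluoro in place of nitro on an aromatic carbon.

Within the data shown here, the only measured change at this place is cyano in place of nitro, and there compound 2 `Cc1cc(CNS(=O)(=O)c2ccc(C#N)cc2)c(C)o1` gives 105000 nM. From the compounds shown here alone, that step, an at least 1.4-fold lower number from compound 1 to compound 2 (0.16 log units; that floor lies within the scatter), has a floor within the scatter, so its true size stays open. It involves a different entering group and offers only indirect guidance for compound 3.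

With this single step as the basis, no change beyond the scatter is expected in this assay, and the estimated step is an at least 1.1-fold lower number from compound 1 to compound 3 (0.06 log units; that floor lies within the scatter). Compound 3 is expected at 130000 nM, with an estimated range from 65000 nM to 260000 nM.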

Compound 3, half-maximal cytotoxic concentration: 138000 nM
Estimate against measurement, compound 3: 1.1-fold (0.03 log units) below; the range from low to high includes it.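

At this position, on an aromatic carbon para to a large group, fluoro and cyano can now be compared as two measured numbers in this assay, and the difference lies within the scatter (a 1.3-fold higher number from compound 2 to compound 3 (0.12 log units; within the scatter)). This is the one pair shown at this place that does not rest on a limit. The step from nitro to fluoro (an at least 1.1-fold lower number from compound 1 to compound 3 (0.04 log units; that floor lies within the scatter)) has only a floor within the scatter, so its true size stays open, as compound 1 gives a limit of the assay and not a number: the limit of > 152000 nM in this assay, at which 1 of the 3 values shown sits.

No step shown at this place has a size beyond the scatter, so it stays open whether an amine or a carboxylic acid here would shift the tolerated concentration. The shared core is the same throughout, which leaves the effect of any change elsewhere, such as a longer chain in place of a methyl group, unknown.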